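The source may hold more compounds than are shown below. What is called first, only, known or untested is meant among the compounds shown, and "the series" means these compounds.

Two compounds with a cyclic peroxide attached to a bicyclic hydrocarbon core and ending in a carboxylic acid have been measured in a functional assay on MDA-N cells (Homo sapiens) for inhibition; on this read-out higher numbers stand for weaker inhibition of growth and lower numbers for stronger inhibition of growth. Compound 1 `C=C1CCC[C@H]2[C@](C)(CC[C@]3(C)CC[C@@H]([C@@H](C)C(=O)O)OO3)[C@@H](C)CC[C@]12C` gives 910 nM in this assay. Compound 2 `C=C1CCCC(C)(C)C1CC[C@@]1(C)CC[C@H]([C@@H](C)C(=O)O)OO1`, which carries a simpler one-ring version of the hydrocarbon part, gives 3520 nM in this assay. Of the two numbers, compound 1 has the lower one, and the gap to compound 2 is beyond the usual scatter of repeated measurements, so compound 1 stands as the stronger inhibitor of growth in this pair.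

Compound 3 `C=C1CCC[C@H]2[C@](C)(CC[C@]3(C)CC[C@H]([C@@H](C)C(=O)O)OO3)[C@@H](C)CC[C@]12C` is next. It differs from compound 1 as follows: the two compounds have the same atoms and bonds and differ only in configuration as drawn: 1 of 7 stereo elements differ; a stereocentre at a saturated ring carbon is drawn S in compound 1 and R in compound 3. Within the data shown here, no measured pair in this set shows what such a change in configuration alone does, so any expectation rests on compound 1 itself. Since the atoms and bonds are unchanged, the step is expected to be modest, with a slight lean toward weaker inhibition of growth, and the expected step from compound 1 to compound 3 is a 1.6-fold higher number from compound 1 to compound 3 (0.22 log units; within the scatter). Compound 3 is therefore estimated at 1500 nM in this assay, with a range from 400 nM to 6000 nM.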

Compound 3, concentration for 50% growth inhibition: 1830 nM
Estimate against measurement, compound 3: 1.2-fold (0.09 log units) below; measured number inside the range.
By their numbers in this assay, from the lowest: compounds 1, 3 and 2 (each within the scatter of the next, the first and the last beyond it).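

Among these compounds, this pair gives the first direct look at the configuration of this saturated ring carbon in this assay, and the step is a 2.0-fold higher number from compound 1 to compound 3 (0.30 log units; within the scatter). Turning this one stereocentre from S to R, with the rest of the molecule as drawn left alone, gives no difference that can be told apart from the spread of repeated measurements, so the two forms cannot be ranked against each other on this read-out. The comparison is a clean one, with no other structural change in the pair to take into account: the fact that compounds 1 and 3 differ only in the configuration as drawn.

On these data alone, it stays open whether the configuration of this carbon would count for as little on the simpler one-ring hydrocarbon part of compound 2, since that compound has no partner differing from it in this one place. Also open, as far as these compounds go, is how the numbers would respond to a change of a different kind, such as a methyl ester or an amide in place of the carboxylic acid.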